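The source may report more compounds than this note shows. Statements on the series, on what has been measured and on what is new or still open speak of the compounds shown alone.

Working notes on the stilbene set.

Of the compounds shown here, two have numbers so far. Compound 1, `COc1cc(/C=C/c2cc(Br)ccc2O)cc(OC)c1`, in a functional assay on MDA-MB-468 cells (Homo sapiens) for antiproliferative activity, read by MTT assay (on this read-out lower numbers stand for stronger inhibition and higher numbers for weaker inhibition), gives 6100 nM. Compound 2, `COc1cccc(/C=C\c2cc(OC)c(OC)c(OC)c2)c1O`, in this assay gives 2600 nM. Going by the values given here, compound 1 therefore stands at the higher of the two numbers, and the gap to compound 2 lies beyond the usual scatter, so compound 2 is the stronger inhibitor of the pair; the two differ in several places at once, and no single step is computed between them, so their values are simply read side by side.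

The next compound, compound 3, `COc1cc(/C=C/c2cc(Br)ccc2O)cc(OC)c1OC`, is not yet measured in this assay. It follows from compound 1 by one change: methoxy in place of hydrogen on an aromatic carbon. Compound 2 also carries three methoxy groups on its core and shows the lower number, which is the only hint available for the direction of this step. Taking that hint, a moderate step to a lower number is expected from compound 1 to compound 3, a 2.4-fold lower number from compound 1 to compound 3 (0.39 log units; beyond the scatter), with the size uncertain. Compound 3 is accordingly estimated at 2500 nM in this assay, with a range from 800 nM to 8000 nM.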

Compound 3, half-maximal inhibitory concentration: 14200 nM
The estimate for compound 3 lay 5.7-fold (0.75 log units) below the measured number; measured number above the stated range.
By their numbers in this assay, from the lowest: compound 2; then compound 1; then compound 3.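

In this assay, going by these compounds alone, methoxy in place of hydrogen on this aromatic carbon, ortho to two methoxy groups and para to a large group, gives a 2.3-fold higher number from compound 1 to compound 3 (0.37 log units; beyond the scatter), the first step in the set that isolates a single change. At this position, then, the added methoxy group moves the number upward, beyond the scatter, so a third methoxy group here does not bring a lower number on this core. Compound 2 also carries three methoxy groups on its core, but it differs from compound 3 in several places, so its lower number says nothing about this position, and no measurement available here bears on why the number rises.

On these data alone, it remains open whether the rise is particular to methoxy or would also appear with another group at the same place, such as an amine or a carboxylic acid. As far as these compounds go, it also remains open whether the same change would move the number in the same direction on a core of the kind seen in compound 2.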